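This account rests on a few compounds, and the source may have more. Where it says the series, first, only, none or still open, it means among the compounds named here.

Measured compounds in an ADME assay on SK-OV-3 cells (Homo sapiens) for cytotoxicity, read by sulforhodamine B assay, with a stated time of 48 h, tested at 10 uM; on this read-out lower numbers stand for less inhibition and higher numbers for more inhibition at the one concentration tested (going by the name of the read-out):
compound 1 `COc1nc2ccc(Br)cc2cc1C(c1ccccc1)n1cc(-c2ccccc2)nn1`: 13.7%
compound 2 `CCCCCCCCc1cn(C(c2ccccc2)c2cc3cc(Br)ccc3nc2OC)nn1`: 2.06%
compound 3 `CCCc1cn(C(c2ccccc2)c2cc3cc(Br)ccc3nc2OC)nn1`: 11.2%

Compound 1 holds the highest of the three numbers. Its nearest neighbour is compound 3, where a number 2.5 percentage points lower from compound 1 to compound 3 (within the scatter). Among the measured compounds shown here, the one step that goes beyond the scatter is a number 11.6 percentage points lower from compound 1 to compound 2 (beyond the scatter). Between the two alkyl-bearing compounds, a number 9.1 percentage points higher from compound 2 to compound 3 (within the scatter). The three numbers therefore span a narrow band, with only the octyl-bearing compound 2 standing clearly apart from compound 1.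

Compound 4 `COc1nc2ccc(Br)cc2cc1C(c1ccccc1)n1cc(-c2cccc(F)c2)nn1` has not yet been measured. It differs from compound 1 as follows: fluoro in place of hydrogen on an aromatic carbon. Cut one bond further out, the change reads phenyl to 3-fluorophenyl, so the aryl group on the triazole is kept and only a fluoro is added to it.

For the measured compounds named here, no measured step bears directly on this change. Going by the values given here, the two steps from compound 1 swap the whole phenyl for an alkyl chain; neither adds a substituent to a ring, and the fluoro-bearing ring appears in no measured compound. The closest analogy, compound 1 to compound 3, stayed within the scatter, and even the larger swap to octyl moved the number only modestly. The step of a number 0.3 percentage points higher from compound 1 to compound 4 (within the scatter) is therefore expected to stay within the scatter. Compound 4 is estimated at 14%, with a range from 3% to 27%.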

Compound 4, a percentage reported as inhibition, at one concentration (the size of the read-out at that concentration, not a potency): 12.7%
Estimate against measurement, compound 4: 1.3 percentage points above, and the stated range covers the measured number.
By their numbers in this assay, from the lowest: compounds 2, 3, 4 and 1 (each within the scatter of the next, the first and the last beyond it).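

In this assay, among the compounds shown here, adding a fluoro on an aromatic carbon of the aryl group, meta to a large group, gives a number 1 percentage points lower from compound 1 to compound 4 (within the scatter) and is the one reading here of a substituent added to this ring, where the earlier steps replaced the whole group. Against the alkyl compounds, the 3-fluorophenyl group gives a number 1.5 percentage points higher from compound 3 to compound 4 (within the scatter) and a number 10.6 percentage points higher from compound 2 to compound 4 (beyond the scatter), so the octyl-bearing compound 2 stays clearly apart from compound 4 as it does from compound 1, while the propyl-bearing compound 3 stays within the scatter of both. No measurement on hand offers an explanation for these numbers.

A single fluoro at one ring position leaves open what a chloro, a methoxy, an amine or a carboxylic acid would do on the same ring, and what a fluoro would do on the other ring carbons. As far as these compounds go, with every compound read at one concentration in this assay, potency also stays open, as does the way the number runs with chain length between propyl and octyl.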